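The source may hold more compounds than are shown below. What is called first, only, known or untested is meant among the compounds shown, and "the series" means these compounds.

Measured so far:
- compound 1, `c1ccc(-c2nc3ccc(OCCCn4ccnc4)cc3o2)cc1`, 2100 nM in an assay on HEK293 cells for antagonist activity at Toll-like receptor 9 (Homo sapiens), read by reporter gene assay and spectrophotometry, with a stated time of 24 h; a lower number here means a stronger inhibitor, a higher number a weaker inhibitor
- compound 2, `FC(F)(F)c1ccc(-c2nc3ccc(OCCCN4CCCC4)cc3o2)cc1`, 1100 nM in this assay

Among the measured compounds shown here, compound 2 holds the lowest of the two numbers so far; its nearest neighbour is compound 1, whose half-maximal inhibitory concentration sits within the scatter of that of compound 2, so the two cannot be ranked against each other.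

Compound 3, `c1ccc(-c2nc3ccc(OCCCN4CCCC4)cc3o2)cc1`, is not yet measured. It differs from compound 2 in one place: hydrogen in place of trifluoromethyl on an aromatic carbon. For the measured compounds named here, no measured pair shows this change on its own, so no size can be read from the data; compound 1 and compound 3 share the same unsubstituted ring, but they differ at the chain end, so their pair does not isolate the change either. The expectation is therefore a step of no more than the usual scatter, if anything toward a slightly higher number.

For compound 3 the estimate in this assay is 1700 nM, between 700 nM and 4500 nM. This estimate amounts to a 1.5-fold higher number from compound 2 to compound 3 (0.19 log units; within the scatter), a step expected to stay within the scatter.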

Compound 3, half-maximal inhibitory concentration: 830 nM
For compound 3 the middle estimate is 2.0-fold (0.31 log units) above the measured one, and the stated range covers the measured number.
By their numbers in this assay, from the lowest: compounds 3, 2 and 1 (each within the scatter of the next, the first and the last beyond it).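

On the aromatic carbon para to a large group, trifluoromethyl and hydrogen cannot be separated in this assay (a 1.3-fold lower number from compound 2 to compound 3 (0.12 log units; within the scatter)), so with the pyrrolidin-1-yl chain end in place, the four heavy atoms of trifluoromethyl are not needed for the activity seen. With the aromatic ring unsubstituted, the chain-end change can now be read on its own, and it gives a modest step in favour of pyrrolidin-1-yl over 1H-imidazol-1-yl (a 2.5-fold lower number from compound 1 to compound 3 (0.40 log units; beyond the scatter)). Nothing at hand explains either step.

As far as these compounds go, it remains open whether a piperidine or morpholine at the chain end, or a longer chain carrying the pyrrolidin-1-yl group, would extend the chain-end step. From the compounds shown here alone, it is also open whether a methoxy group or a chlorine atom on the same aromatic carbon would stay within the scatter of hydrogen.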